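From isopropyl to 3-methyl-1,2-oxazol-5-yl on the shared core

The compounds below may be only part of what the source reports. "The series", "measured", "known", "first", "only" and "open" are said of these compounds alone.

In an ADME assay on microsomes from liver (Homo sapiens) for metabolic stability, with a stated time of 60 min, tested at 1 uM (a higher number here means that more of the compound is left, a lower number that less of the compound is left), compound 3 (`COc1cc(-c2cnn3cc(OC)c(C(C)C)nc23)ccn1`) stands at 40% and sits level, within the scatter, with compound 1 (`COc1cc(-c2cnn3cc(OC)c(-c4cnn(C)c4)nc23)ccn1`) at 43% in the same test, while compound 2 (`CNc1nc2c(-c3ccnc(OC)c3)cnn2cc1OC`) reaches 63% and stands clear of both. Compound 4 (`COc1cc(-c2cnn3cc(OC)c(-c4cc(C)no4)nc23)ccn1`) carries 3-methyl-1,2-oxazol-5-yl in place of isopropyl on an aromatic carbon, next to the ring nitrogen and ortho to a methoxy group (3-methyl-1,2-oxazol-5-yl in place of isopropyl on an aromatic carbon). The nearest measured exchange swaps 1-methyl-1H-pyrazol-4-yl for isopropyl at this same place, and it is a number 3 percentage points lower from compound 1 to compound 3 (within the scatter) with no change beyond the scatter. The two steps involving methylamino, a number 20 percentage points higher from compound 1 to compound 2 (beyond the scatter) and a number 23 percentage points lower from compound 2 to compound 3 (beyond the scatter) as well, are modest, but compound 4 carries no methylamino, so they bear on it only weakly. No measurement exists yet for 3-methyl-1,2-oxazol-5-yl itself, which keeps the range wide. No step beyond the scatter is therefore expected, the estimate being a number 4 percentage points higher from compound 3 to compound 4 (within the scatter) for this change. In this assay the expected value of compound 4 is 44% with a range from 25% to 63% on measurement.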

Compound 4, percent of the compound remaining: 31%
Estimate against measurement, compound 4: 13 percentage points above; the range from low to high includes it.
By their numbers in this assay, from the lowest: compounds 4, 3 and 1 (each within the scatter of the next, the first and the last beyond it); then compound 2.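

In this assay, within the data shown here, the exchange of isopropyl for 3-methyl-1,2-oxazol-5-yl reads as a number 9 percentage points lower from compound 3 to compound 4 (within the scatter), but set against 1-methyl-1H-pyrazol-4-yl the same group gives a number 12 percentage points lower from compound 1 to compound 4 (beyond the scatter), the first exchange at this place not involving methylamino to pass beyond the scatter. Methylamino now also has a large step to its name, a number 32 percentage points lower from compound 2 to compound 4 (beyond the scatter), so compound 2 stays clear of all three other compounds, and the groups at this place now span a wider spread than the earlier compounds showed. Nothing at hand explains why 3-methyl-1,2-oxazol-5-yl and methylamino part so far at this place.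

The compounds shown leave open whether the standing of compound 2 belongs to methylamino alone or would carry over to another amine, such as dimethylamino or morpholine, on the same aromatic carbon. They also leave open whether the methyl on the 3-methyl-1,2-oxazol-5-yl ring has any part in the result, which the plain unsubstituted 1,2-oxazol-5-yl group or an ethyl at that ring position could test.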